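This account rests on a few compounds, and the source may have more. Where it says the series, first, only, none or still open, it means among the compounds named here.

Measured so far:
- compound 1 `CC(C)OC(=O)C1CN(C(=O)c2cccc(Cl)c2)CC(C)(C)c2cc(C#N)[nH]c21`: 17 ug/mL
- compound 2 `CC(C)OC(=O)C1CN(C(=O)c2ccc(F)cc2)CC(C)(C)c2cc(C#N)[nH]c21`: > 100 ug/mL (a limit of the assay, not a number)

In a physicochemical assay for solubility, at pH 7.4 (a higher number here means a more soluble compound, a lower number a less soluble compound), compound 1 gives 17 ug/mL as a true number. Compound 2 is known only as a limit, > 100 ug/mL (see (the limit of > 100 ug/mL in this assay, at which 1 of the 2 values shown sits)).

Compound 3 `CC(C)OC(=O)C1CN(C(=O)C2CCOCC2)CC(C)(C)c2cc(C#N)[nH]c21` is not yet measured. Its change from compound 2 is oxan-4-yl in place of 4-fluorophenyl on a carbonyl carbon and amounts to oxan-4-yl in place of 4-fluorophenyl on a carbonyl carbon.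

For the measured compounds named here, the only measured step at this place is an at least 5.8-fold higher number from compound 1 to compound 2 (0.76 log units; beyond the scatter) and it lies beyond the scatter. It shows that the group on this carbonyl carbon can move the read-out, but it exchanges one substituted phenyl for another, so it gives no firm direction for the present change. Compound 2 at > 100 ug/mL also leaves the starting point open. The working expectation in this assay is therefore no step beyond the scatter, and another limit would not be surprising.

The estimated step is a step that the limit leaves unreadable from compound 2 to compound 3 (an expectation only). The expected value for compound 3 is 110 ug/mL (expected range 45 ug/mL to 250 ug/mL).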

Compound 3, solubility: > 100 ug/mL
Compound 3: only a limit was reported; the forecaster's own chance of this, stated with the estimate: 55%; the middle value is on the limit's open side.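

In this assay the series now holds an at least 5.8-fold higher number from compound 1 to compound 3 (0.76 log units; beyond the scatter), so the gain seen with 4-fluorophenyl is no longer tied to a phenyl group on this carbonyl carbon: the non-aromatic oxan-4-yl, with its one hydrogen-bond acceptor, also stands clear of 3-chlorophenyl. The entry for compound 3 in this assay is a limit of the assay and not a number. Compound 2 and compound 3 are both known only as limits, so the step between them cannot be read and no order can be given for 4-fluorophenyl and oxan-4-yl: the limit of > 100 ug/mL in this assay, at which 2 of the 3 values shown sit.

As far as these compounds go, whether other kinds of group on this carbonyl carbon, such as an amine, a carboxylic acid or an open alkyl chain, would stay with compound 2 and compound 3 or fall back towards compound 1 at 17 ug/mL remains open. Also open, from the compounds shown here alone, is whether the chlorine or its place on the ring sets 3-chlorophenyl apart from 4-fluorophenyl, as these two groups differ in both halogen and place.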